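The source may report more compounds than this note shows. Statements on the series, on what has been measured and on what is new or still open speak of the compounds shown alone.

Three compounds from one series have been run through a functional assay on MCF7 cells (Homo sapiens) for inhibition, read by fluorescence, with a stated time of 72 h; on this read-out lower numbers stand for stronger inhibition of growth and higher numbers for weaker inhibition of growth. Compound 1, with the structure `CCCCCCn1cnc2c(Nc3ccc(O)cc3)nc(N[C@H]3CC[C@H](N)CC3)nc21`, gives 3500 nM in this assay. Compound 2, with the structure `CC(C)CCn1cnc2c(Nc3ccccc3)nc(N[C@H]3CC[C@H](N)CC3)nc21`, gives 5400 nM, and compound 3, with the structure `CC(C)=CCn1cnc2c(Nc3cccc(Cl)c3)nc(N[C@H]3CC[C@H](N)CC3)nc21`, gives 4200 nM. Although the number for compound 1 sits at the low end of the three, its gaps to compound 3 and to compound 2 both fall inside the usual scatter of repeated runs, so the three compounds cannot be told apart on these data.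

Compound 4, with the structure `CCCCCCn1cnc2c(Nc3ccc(Cl)cc3)nc(N[C@H]3CC[C@H](N)CC3)nc21`, has not yet been measured. It is built from compound 1 by a single change: chloro in place of hydroxy on an aromatic carbon. Within the data shown here, no pair of measured compounds shows this same change, so there is no directly comparable step to lean on. Given that all three measured compounds cluster together, the expectation for compound 4 is a step of a 1.1-fold higher number from compound 1 to compound 4 (0.06 log units; within the scatter), that is, nothing beyond the scatter in either direction. Compound 4 is therefore estimated at 4000 nM, with a likely range from 1500 nM to 10000 nM.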

Compound 4, concentration for 50% growth inhibition: 4200 nM
Beside the measured number, compound 4's estimate is 1.1-fold (0.02 log units) below it; measured number inside the range.
By their numbers in this assay, from the lowest: compounds 1, 3, 4 and 2 (each within the scatter of the next).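

Replacing hydroxy with chloro at this position gives the first one-place comparison among these compounds: in this assay the change produces a 1.2-fold higher number from compound 1 to compound 4 (0.08 log units; within the scatter) and so stays within the scatter. Compound 1 and compound 4 therefore cannot be told apart, even though the swap takes away the hydrogen-bond donor and acceptor counted for hydroxy. On these data, growth inhibition does not depend on which of these two groups sits on the ring, and nothing available explains why.

On these data alone, whether an amine, a carboxylic acid or a methoxy group at the same position would shift the number beyond the scatter remains open. So does whether hydroxy and chloro would still match with a different chain on the shared core.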